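Carbonyl Replaced by Sulfonyl on the Shared Core

A few compounds are considered here, and "the series" means these few. Any claim that something is new, unique, unknown or untested is made for them only; others in the source may bear on it.

Compound 1 `O=C(Nc1cccc(/C=C/C(=O)c2nc3ccccc3[nH]2)c1)c1ccc(Br)cc1` carries a (4-bromophenyl)carbonyl on a nitrogen on an aromatic ring. Going by the values given here, in a functional assay on 143B cells (Homo sapiens) for antiproliferative activity, read by MTT assay, with a stated time of 48 h (on this read-out higher numbers stand for weaker inhibition and lower numbers for stronger inhibition), compound 1 gives 7310 nM, which is the lowest of the two numbers measured so far. Its nearest neighbour is compound 2 `O=C(/C=C/c1cccc(NS(=O)(=O)c2ccc(Cl)cc2)c1)c1nc2ccccc2[nH]1`, which in this assay gives 7450 nM. The step of a 1.0-fold higher number from compound 1 to compound 2 (0.01 log units; within the scatter) shows that exchanging the carbonyl-linked aryl for a sulfonyl-linked aryl at that nitrogen left the read-out unchanged.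

Compound 3 `Cc1cccc(S(=O)(=O)Nc2cccc(/C=C/C(=O)c3nc4ccccc4[nH]3)c2)c1` is not yet measured. It differs from compound 1 as follows: (3-methylphenyl)sulfonyl in place of (4-bromophenyl)carbonyl on a nitrogen on an aromatic ring. The step from compound 1 to compound 2 bears on this change, since it also brought in a sulfonyl-linked aryl at the same nitrogen and produced no step beyond the scatter; the methyl in place of a halogen is not covered by any measured pair. Compound 3 is therefore expected to show no step beyond the scatter, a 1.0-fold higher number from compound 1 to compound 3 (0.01 log units; within the scatter), with an estimated value of 7500 nM and a range from 3000 nM to 18000 nM.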

Compound 3, half-maximal inhibitory concentration: 791 nM
The estimate for compound 3 lay 9.5-fold (0.98 log units) above the measured number; measured number below the stated range.
By their numbers in this assay, from the lowest: compound 3; then compounds 1 and 2 (each within the scatter of the next).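

With the sulfonyl held in place, the aryl group on it proved decisive in this assay: 3-methylphenyl in place of 4-chlorophenyl on the sulfonyl sulfur gave a 9.4-fold lower number from compound 2 to compound 3 (0.97 log units; beyond the scatter), a change the earlier pair could not reveal. Against the carbonyl-linked compound, (3-methylphenyl)sulfonyl in place of (4-bromophenyl)carbonyl on the same nitrogen gave a 9.2-fold lower number from compound 1 to compound 3 (0.97 log units; beyond the scatter), so the sulfonyl link alone does not set the number at this position. Nothing available accounts for the size of these steps.

The compounds shown do not separate the exchange of chlorine for methyl from the different ring position of the two substituents, since 3-chlorophenyl and 4-methylphenyl are not among them. From the compounds shown here alone, how a 3-methoxyphenyl or 3-aminophenyl on the sulfonyl sulfur would read also remains open.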